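Fluoro to Chloro on Two Related Compound Pairs

The compounds below may be only part of what the source reports. "The series", "measured", "known", "first", "only" and "open" are said of these compounds alone.

Compound 3, `Cc1ccc(C)c(N2CCN(C(=O)c3oc(C)nc3-c3ccccc3F)CC2)c1`, is the reference point of this small set. In a functional assay on HL-60 cells (Homo sapiens) for inhibition, read by MTT assay, with a stated time of 72 h (on this read-out lower numbers stand for stronger inhibition and higher numbers for weaker inhibition), compound 3 gives 319 nM. Compound 2, `Cc1ccc(C)c(N2CCN(C(=O)c3oc(C)nc3-c3ccccc3Cl)CC2)c1`, is its close relative. For compound 2 the result in this assay is reported only as a limit, > 1000 nM, not as a number. The change between the two is chloro in place of fluoro on an aromatic carbon, and it made an at least 3.1-fold higher number from compound 3 to compound 2 (0.49 log units; beyond the scatter), a move toward weaker inhibition. That one of the three results recorded sits at the limit of > 1000 nM in this assay, at which 1 of the 3 values shown sits, shows where the weaker member of this pair came to rest.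

Compound 1, `O=C(c1oc(C(F)(F)F)nc1-c1cccc(F)c1)N1CCN(c2cccc(Cl)c2)CC1`, carries a different core; how its core differs from that of compound 3 is not broken down here. In this assay compound 1 gives "not active" (no number reported), with no number behind it.

Compound 4, `O=C(c1oc(C(F)(F)F)nc1-c1cccc(Cl)c1)N1CCN(c2cccc(Cl)c2)CC1`, has not yet been measured. It differs from compound 1 by chloro in place of fluoro on an aromatic carbon. The place is not the same as in the measured pair: there the entering chloro stood ortho to a large group, here it stands meta to a large group, so this is the same kind of change rather than the same change. In the measured pair the step went toward weaker inhibition, and compound 1 itself starts from a result without a number, so compound 4 is expected to end at or past the limit of this assay. Compound 4 is expected to give 3000 nM, with a plausible range from 800 nM to 20000 nM.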

Compound 4, half-maximal inhibitory concentration: "not active" (no number reported)
No number was reported for compound 4; the estimate stays without a comparison.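

In this assay compound 1 gives "not active" (no number reported) and compound 4 gives "not active" (no number reported); with no number on either side, no new step can be read between the two. The compounds shown leave open how the change from 3-fluorophenyl to 3-chlorophenyl acts on inhibition in this series, and whether the direction seen with chloro in place of fluoro in the other pair also holds here.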